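The source may report more compounds than this note shows. Statements on the series, on what has been measured and on what is new or still open speak of the compounds shown alone.

Within the data shown here, in a functional assay on cells for antagonist activity at C-X-C chemokine receptor type 4 (Homo sapiens), read by fluorescence and calcium flux, with stated times of 25 min and 90 s (on this read-out higher numbers stand for weaker inhibition and lower numbers for stronger inhibition), compound 2 `c1cncc(CNCCCCN(C[C@H]2Cc3ccccc3CN2)[C@H]2CCCc3cccnc32)c1` gives 15.3 nM, the lowest of the two numbers measured so far; its nearest neighbour is compound 1 `c1cncc(CN(CCCCN(C[C@H]2Cc3ccccc3CN2)[C@H]2CCCc3cccnc32)Cc2cccnc2)c1`, which in this assay gives 471 nM. Among the measured compounds shown here, the one measured step, a 31-fold lower number from compound 1 to compound 2 (1.49 log units; beyond the scatter), was large and is the only step that touches the amine nitrogen. Compound 3 `NCc1cccc(CN(C[C@H]2Cc3ccccc3CN2)[C@H]2CCCc3cccnc32)c1` has not been measured; it differs from compound 2 by 3-(aminomethyl)phenyl in place of 3-(((pyridin-3-yl)methyl)amino)propyl on a saturated chain carbon bound to an amine nitrogen. For the measured compounds named here, no measured step alters the chain itself, so the step from compound 1 to compound 2 bears on compound 3 only in that both compound 2 and compound 3 keep a hydrogen on the terminal amine, the feature whose loss cost so much in compound 1. Compound 3 is therefore expected to stay in the neighbourhood of compound 2, with a small move toward a higher number, a 2.6-fold higher number from compound 2 to compound 3 (0.42 log units; beyond the scatter), and its estimated value is 40 nM with a range from 8 nM to 200 nM.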

Compound 3, half-maximal inhibitory concentration: 292 nM
For compound 3 the middle estimate is 7.3-fold (0.86 log units) below the measured one, outside the stated range (above it).
By their numbers in this assay, from the lowest: compound 2; then compounds 3 and 1 (each within the scatter of the next).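

In this assay, putting 3-(aminomethyl)phenyl in place of 3-(((pyridin-3-yl)methyl)amino)propyl on a saturated chain carbon bound to an amine nitrogen gives a 19-fold higher number from compound 2 to compound 3 (1.28 log units; beyond the scatter), a large step. The earlier step changed only what sat on the terminal amine, whereas this one shows that the number also depends strongly on the group at this place: a hydrogen on the terminal amine does not by itself preserve the low number of compound 2. No evidence is available to explain the size of this step.

As far as these compounds go, the whole group changes at once, so it remains open whether the step follows from the ring, the chain or the loss of the pyridin-3-yl unit. A plain 3-aminopropyl chain at this place would begin to separate these parts.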